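This account rests on a few compounds, and the source may have more. Where it says the series, first, only, none or still open, it means among the compounds named here.

Working notes on the series. In a functional assay on K562 cells (Homo sapiens) for antiproliferative activity, read by MTT assay, with a stated time of 48 h (on this read-out lower numbers stand for stronger inhibition and higher numbers for weaker inhibition), compound 1 `Cn1cc(C2=C(c3nn(CCCN4CCCCC4)c4ncccc34)C(=O)N(c3ccccc3)C2=O)c2ccccc21` gives 3790 nM and compound 2 `Cn1cc(C2=C(c3nn(CCCN4CCCCC4)c4ncccc34)C(=O)N(c3cccc4ccccc34)C2=O)c2ccccc21` gives 3180 nM, so the two sit level within the scatter. Compound 3 `Cn1cc(C2=C(c3nn(CCCN4CCCCC4)c4ncccc34)C(=O)N(c3ccccn3)C2=O)c2ccccc21` reaches only a limit of the assay, > 100000 nM. Compound 1 therefore stands with compound 2 among the two true numbers in the set.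

Compound 4 `Cn1cc(C2=C(c3nn(CCCn4cccc4)c4ncccc34)C(=O)N(c3ccccc3)C2=O)c2ccccc21` keeps the core of compound 1 and changes the chain end: 1H-pyrrol-1-yl in place of piperidin-1-yl on a saturated chain carbon, three bonds along the chain from an aromatic nitrogen. The group on the amide-type nitrogen stays phenyl.

For the measured compounds named here, no measured step touches this chain end, so the evidence is indirect. The measured steps all lie at the amide-type nitrogen, and they point two ways: a 1.2-fold lower number from compound 1 to compound 2 (0.08 log units; within the scatter), against an at least 26-fold higher number from compound 1 to compound 3 (1.42 log units; beyond the scatter). They show that this assay can tolerate one change in this series and lose a great deal on another, but they do not fix the size of a change made elsewhere. A moderate move to a higher number is expected, with a wide margin, and a large loss like that seen with compound 3 is not ruled out.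

The expected change is a 2.4-fold higher number from compound 1 to compound 4 (0.38 log units; beyond the scatter). For compound 4 the estimated value is 9000 nM, with an expected range of 2500 nM to 40000 nM.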

Compound 4, half-maximal inhibitory concentration: 36600 nM
The estimate for compound 4 lay 4.1-fold (0.61 log units) below the measured number; the measured number falls inside the stated range.
By their numbers in this assay, from the lowest: compounds 2 and 1 (each within the scatter of the next); then compound 4. At a limit, above all of these: compound 3.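

For the compounds shown here, the chain end matters in this assay: a 9.7-fold higher number from compound 1 to compound 4 (0.98 log units; beyond the scatter), and this is the first measured step away from the amide-type nitrogen, so the amide-type nitrogen is not the only place where the number can move. With phenyl held on the amide-type nitrogen, 1H-pyrrol-1-yl in place of piperidin-1-yl still leaves a true number that can be sized, unlike a value resting at the limit of the assay: the limit of > 100000 nM in this assay, at which 1 of the 4 values shown sits. This single pair ties the loss to this one swap on the 3-carbon propyl chain end and gives no cause for it.

From the compounds shown here alone, whether a morpholin-4-yl group, a dimethylamino group or another open-chain amine at the chain end would hold the number of compound 1 stays open, as does the effect of a shorter or longer chain carrying the piperidin-1-yl group. Going by these compounds, it is also open whether the same swap gives a step of like size with naphthalen-1-yl on the amide-type nitrogen.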